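This account rests on a few compounds, and the source may have more. Where it says the series, first, only, none or still open, it means among the compounds named here.

Measured so far in an assay for inhibition of inositol hexakisphosphate kinase 3 (Homo sapiens), read by colorimetric assay, coupled enzyme assay and malachite green, with a stated time of 120 min, in the presence of a further agent that is not named here; on this read-out higher numbers stand for weaker inhibition and lower numbers for stronger inhibition:

Compound 1, `O=C(O)/C=C/c1ccc2noc(-c3ccc(Oc4ccccc4)cc3)c2c1`: 760 nM
Compound 2, `O=C(O)/C=C/c1ccc2noc(-c3ccc(-c4ccccc4)cc3)c2c1`: 200 nM
Compound 3, `O=C(O)c1ccc2noc(-c3cccc(-c4ccccc4)c3)c2c1`: 840 nM

Compound 2 and compound 1 differ in one place: phenoxy in place of phenyl on an aromatic carbon. That change produced a 3.8-fold higher number from compound 2 to compound 1 (0.58 log units; beyond the scatter). Compound 3 carries a different core, and how its core differs from that of compound 2 is not broken down here; what the two values show is that compound 2 gives a lower number in this assay than compound 3, while compound 3 and compound 1 lie within the usual scatter of each other.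

Compound 4, `O=C(O)c1ccc2noc(-c3cccc(Oc4ccccc4)c3)c2c1`, has not yet been measured. It stands to compound 3 as compound 1 stands to compound 2: phenoxy in place of phenyl on an aromatic carbon. The two place lines are not identical, since in the first pair the group sits para to a large group and in the second pair it sits meta to a large group, so this is the same kind of change rather than the same change. Among the measured compounds shown here, the only guide is the single earlier step, a 3.8-fold higher number from compound 2 to compound 1 (0.58 log units; beyond the scatter), and the core of compound 3 is not the core of compound 2, so the expectation is held loosely. On that basis the step from compound 3 to compound 4 in this assay is expected to be a 3.0-fold higher number from compound 3 to compound 4 (0.47 log units; beyond the scatter), in the same direction as the earlier one because of a 3.8-fold higher number from compound 2 to compound 1 (0.58 log units; beyond the scatter) but with wide uncertainty. Compound 4 is therefore estimated at 2500 nM, expected to fall between 800 nM and 8000 nM.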

Compound 4, half-maximal inhibitory concentration: 850 nM
Compound 4: middle estimate off by 2.9-fold (0.47 log units), on the high side, within the range that was stated.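

In this assay, phenoxy in place of phenyl on the core of compound 3 gives a 1.0-fold higher number from compound 3 to compound 4 (0.01 log units; within the scatter), so on this core the exchange leaves no readable change. Set beside the earlier step, the same kind of change does not carry over in size from one core to the other: the same change on two cores in this assay, a 3.8-fold higher number (0.58 log units; beyond the scatter) from compound 2 to compound 1 and a 1.0-fold higher number (0.01 log units; within the scatter) from compound 3 to compound 4, 3.8-fold (0.57 log units) apart, beyond the scatter of two such steps. Among the compounds shown here, this shows that the size of the step on one core cannot be taken as a guide to its size on the other, but with only one pair on each core it does not show what accounts for the gap, since the two pairs differ both in their cores and in where the group sits, and in the new pair it is meta to a large group.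

The compounds shown leave open whether other groups at this place, such as a benzyl group, a cyclohexyl ring or an amine linking the two rings, would give steps that stay alike or differ across the two cores. They also leave open whether the gap between the two steps would persist if the carboxylic acid on each core gave way to an amide or an ester.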